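This account rests on a few compounds, and the source may have more. Where it says the series, first, only, none or still open, it means among the compounds named here.

Compound 1 `Cc1c(-c2ccc(Cc3ccc(C(C)(O)C(F)(F)F)cc3)cc2)[nH]c2cccc(F)c2c1=O` and compound 2 `Cc1c(-c2ccc(Cc3ccc(C(O)C(F)(F)F)cc3)cc2)[nH]c2cccc(F)c2c1=O` share one core, while compound 3 `CCN(C)c1ccc(Oc2ccc(-c3[nH]c4cccc(F)c4c(=O)c3C)cc2F)cc1` and compound 4 `Cc1c(-c2ccc(Oc3ccc(N(C)C)cc3)c(F)c2)[nH]c2cccc(F)c2c1=O` share another; the difference between the two cores is not broken down here. In an ADME assay on Huh7.5.1 cells (Homo sapiens) for cytotoxicity, read by WST assay, with a stated time of 48 h (a higher number here means that more compound is tolerated, a lower number that less compound is tolerated), compound 1 gives > 2500 nM, which is a limit of the assay rather than a number. In this assay compound 2 gives > 10000 nM, also a limit. The change between them is hydrogen in place of methyl on a saturated chain carbon bound to an aromatic carbon, an oxygen on a saturated carbon and a saturated chain carbon, and it made a step that the two limits leave unreadable from compound 1 to compound 2, since the two readings rest on the limit of > 2500 nM in this assay, at which 1 of the 3 values shown sits, and (the limit of > 10000 nM in this assay, at which 2 of the 3 values shown sit). In this assay compound 3 gives > 10000 nM, again a limit. From compound 3 to compound 4 the change is hydrogen in place of methyl on a saturated chain carbon bound to a nitrogen on an aromatic ring, the same kind of change as before, though the place differs: a saturated chain carbon bound to an aromatic carbon, an oxygen on a saturated carbon and a saturated chain carbon in the first pair, a saturated chain carbon bound to a nitrogen on an aromatic ring in the second. Because compound 3 sits at the limit of > 10000 nM in this assay, at which 2 of the 3 values shown sit, compound 4 is expected to stay at or past that limit, a step estimated as a step that the limit leaves unreadable from compound 3 to compound 4. Compound 4 is expected to give about 15000 nM, estimated between 5000 nM and 50000 nM.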

Compound 4, half-maximal cytotoxic concentration: > 10000 nM
Compound 4: a limit, no number (the forecaster's own chance of this, stated with the estimate: 85%); the middle value does not contradict the limit.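

Compound 3 and compound 4 both give a limit rather than a number in this assay, so the change from ethyl(methyl)amino to dimethylamino yields no readable step: the limit of > 10000 nM in this assay, at which 3 of the 4 values shown sit.

The compounds shown leave open the actual concentration at which each one harms these cells, and whether replacing methyl with hydrogen shifts it at all.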